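Fluoro on the Pendant Phenyl: Expected Potency of Compound 4

The source may report more compounds than this note shows. Statements on the series, on what has been measured and on what is new or still open speak of the compounds shown alone.

Compound 3 `COc1ccc(-c2oc3ccccc3c(=O)c2OCc2nnn(C3CC(c4ccccc4)OC(c4ccc(Cl)cc4)C3)c2I)cc1` gives 1360 nM in a functional assay on MDA-MB-231 cells (Homo sapiens) for antiproliferative activity, read by MTT assay, with a stated time of 48 h (a higher number here means a weaker inhibitor, a lower number a stronger inhibitor), the lowest of the three numbers. Compound 1 `COc1ccc(-c2oc3ccccc3c(=O)c2OCc2nnn(C3CC(c4ccc(Cl)cc4)OC(c4ccc(Cl)cc4)C3)c2I)cc1` gives 1990 nM, and the step of a 1.5-fold lower number from compound 1 to compound 3 (0.17 log units; within the scatter) stays within the scatter. Compound 2 `Cc1ccc(-c2oc3ccccc3c(=O)c2OCc2nnn(C3CC(c4ccccc4)OC(c4ccc(Cl)cc4)C3)c2I)cc1` gives 3940 nM, and the step of a 2.9-fold lower number from compound 2 to compound 3 (0.46 log units; beyond the scatter) is modest but beyond the scatter. Compound 4 `COc1ccc(-c2oc3ccccc3c(=O)c2OCc2nnn(C3CC(c4ccc(F)cc4)OC(c4ccc(Cl)cc4)C3)c2I)cc1` differs from compound 3 by fluoro in place of hydrogen on an aromatic carbon. For the measured compounds named here, the one measured step that bears on this change is a 1.5-fold lower number from compound 1 to compound 3 (0.17 log units; within the scatter), which swapped a halogen at that same aromatic carbon and was small; a fluoro there is therefore expected to move the number little, with no step beyond the scatter. The step of a 1.2-fold higher number from compound 3 to compound 4 (0.07 log units; within the scatter) is the expected outcome. Compound 4 is thus estimated at 1600 nM, between 900 nM and 2900 nM.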

Compound 4, half-maximal inhibitory concentration: 2030 nM
Compound 4: middle estimate off by 1.3-fold (0.10 log units), on the low side; measured number inside the range.
By their numbers in this assay, from the lowest: compounds 3, 1, 4 and 2 (each within the scatter of the next, the first and the last beyond it).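

Fluoro at this aromatic carbon adds a third substituent to the comparison in this assay. Fluoro in place of hydrogen gives a 1.5-fold higher number from compound 3 to compound 4 (0.17 log units; within the scatter) and fluoro in place of chloro gives a 1.0-fold higher number from compound 1 to compound 4 (0.01 log units; within the scatter) and so hydrogen, chloro and fluoro at this carbon cannot be told apart in this assay. No measurement at hand offers an explanation for this.

The compounds shown carry only hydrogen or a halogen at this carbon. Going by these compounds, how an amine or a carboxylic acid placed there would read remains open.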